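The source may hold more compounds than are shown below. What is called first, only, known or untested is meant among the compounds shown, and "the series" means these compounds.

Measured so far in a functional assay on HepG2 cells (Homo sapiens) for cytotoxicity, read by MTT assay, with a stated time of 48 h; a higher number here means a weaker inhibitor, a lower number a stronger inhibitor:
compound 1 `COc1cccc(/C=N/NC(=O)CSc2nnc(-c3ccncc3)o2)c1`: 9170 nM
compound 2 `O=C(CSc1nnc(-c2ccncc2)o1)N/N=C/c1ccccc1O`: 3510 nM
compound 3 `O=C(CSc1nnc(-c2ccncc2)o1)N/N=C/c1cc(Cl)ccc1O`: 3970 nM

Compound 3 stands second highest of the three numbers in this assay. Its nearest neighbour is compound 2, a 1.1-fold higher number from compound 2 to compound 3 (0.05 log units; within the scatter); the gap to compound 1 is wider, a 2.3-fold lower number from compound 1 to compound 3 (0.36 log units; beyond the scatter).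

Compound 4 `O=C(CSc1nnc(-c2ccncc2)o1)N/N=C/c1cc(Br)ccc1O` differs from compound 3 in one place: bromo in place of chloro on an aromatic carbon. Among the measured compounds shown here, the only measured step at this aromatic carbon is the one from hydrogen to chloro, a 1.1-fold higher number from compound 2 to compound 3 (0.05 log units; within the scatter), which stayed within the scatter. For the measured compounds named here, no measured step exchanges one halogen for another here. On that basis a step of no size beyond the scatter is expected in this assay, a 1.0-fold higher number from compound 3 to compound 4 (0.00 log units; within the scatter). Compound 4 is estimated at 4000 nM, with a range of 2000 nM to 8000 nM.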

Compound 4, half-maximal inhibitory concentration: 6490 nM
Beside the measured number, compound 4's estimate is 1.6-fold (0.21 log units) below it; measured number inside the range.
By their numbers in this assay, from the lowest: compounds 2, 3, 4 and 1 (each within the scatter of the next, the first and the last beyond it).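

In this assay exchanging chloro for bromo on this aromatic carbon, para to a hydroxy group, stays within the scatter (a 1.6-fold higher number from compound 3 to compound 4 (0.21 log units; within the scatter)), as does bromo in place of hydrogen (a 1.8-fold higher number from compound 2 to compound 4 (0.27 log units; within the scatter)). Replacing 3-methoxyphenyl with 5-bromo-2-hydroxyphenyl also stays within it (a 1.4-fold lower number from compound 1 to compound 4 (0.15 log units; within the scatter)), unlike the same replacement with the hydrogen or chloro group at this carbon. No measured evidence bears on this result. As far as these compounds go, whether an amine or a carboxylic acid on this carbon would give a step beyond the scatter stays open.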